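From dimethylamino to 2-methoxyphenyl on a shared core

The compounds below may be only part of what the source reports. "The series", "measured", "known", "first", "only" and "open" are said of these compounds alone.

Measured so far in a toxicity assay on THP-1 cells (Homo sapiens) for cytotoxicity; a higher number here means that more compound is needed for the effect, a lower number that less compound is needed:
compound 1 `O=C1CCCN1Cc1n[nH]c(-c2ncc3cccnc3c2O)n1`: > 50100 nM (a limit)
compound 2 `Cc1n[nH]c(-c2ncc3c(N(C)C)ccnc3c2O)n1`: > 50100 nM (a limit)

Compound 2 gives no number in this assay, only the limit > 50100 nM as its result. It stands at the limit of > 50100 nM in this assay, at which 2 of the 2 values shown sit, and nothing yet shows how far past that limit it lies.

Compound 3 `COc1ccccc1-c1ccnc2c(O)c(-c3nc(C)n[nH]3)ncc12` carries 2-methoxyphenyl in place of dimethylamino on an aromatic carbon, opposite the ring nitrogen: 2-methoxyphenyl in place of dimethylamino on an aromatic carbon. The change brings in one six-membered aromatic ring of carbon only.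

Among the compounds with values here, no step between measured compounds is available to scale this change. A modest move toward lower numbers in this assay is expected, though a result within the scatter would be no surprise. The expected change is an at least 1.6-fold lower number from compound 2 to compound 3 (0.22 log units; that floor lies within the scatter) as a rough estimate. For compound 3 the estimated value is 30000 nM with an expected range from 8000 nM to 60000 nM.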

Compound 3, half-maximal effective concentration: > 50100 nM
Compound 3 gave a limit, no number; the forecaster's own chance of this, stated with the estimate: 50%; middle value at least 1.6-fold (0.22 log units) away from the limit.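

Compound 2 and compound 3 both give only a limit, so no step between them can be read in this assay: the limit of > 50100 nM in this assay, at which 3 of the 3 values shown sit.

The compounds shown leave open how far past that limit each one lies, and whether 2-methoxyphenyl in place of dimethylamino changes the number at all.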